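This account rests on a few compounds, and the source may have more. Where it says the series, first, only, none or still open, it means among the compounds named here.

Series notes. Going by the values given here, compound 1 `COc1ccc(C(=O)Nc2ccc3nc(NC(=O)C4CCCCC4)sc3c2)cc1` is one of the two measured members; in a functional assay on WI-38 VA13 cells (Homo sapiens) for cytotoxicity (on this read-out higher numbers stand for an effect only at larger amounts of compound and lower numbers for an effect already at smaller amounts), compound 1 gives 4.9 ug/mL. Compound 2 `CCCC(=O)Nc1nc2ccc(NC(=O)c3c(Cl)cccc3Cl)cc2s1` gives 0.01 ug/mL in this assay, the lower of the two values, with compound 1 standing beyond the scatter at the higher number. The two measured compounds differ in more than one place, so nothing is said here about which part of that difference carries the gap between them. Compound 3 `CCCCNC(=O)Nc1nc2ccc(NC(=O)c3c(Cl)cccc3Cl)cc2s1` is not yet measured. Relative to compound 2 the change is butylamino in place of propyl on a carbonyl carbon. Among the compounds with values here, no pair of measured compounds shows a change of this kind, so the direction of the step rests on the structural difference alone and is uncertain. A modest step toward a higher number, near the edge of the scatter, is expected, a 3.0-fold higher number from compound 2 to compound 3 (0.48 log units; beyond the scatter). For compound 3 the expected value in this assay is 0.03 ug/mL, with a range from 0.005 ug/mL to 0.2 ug/mL.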

Compound 3, half-maximal effective concentration: 0.028 ug/mL
Compound 3: middle estimate off by 1.1-fold (0.03 log units), on the high side, within the range that was stated.
By their numbers in this assay, from the lowest: compound 2; then compound 3; then compound 1.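

In this assay, going by these compounds alone, butylamino in place of propyl on the carbonyl carbon gives a 2.8-fold higher number from compound 2 to compound 3 (0.45 log units; beyond the scatter), the first step read at a single place. The position therefore responds to this change beyond the scatter, yet the size of the step is modest, even though the group entering has the larger heavy-atom count and adds a hydrogen-bond donor. No data at hand give a cause for this step.

The change swaps a propyl chain for a butyl chain and also brings in the amino nitrogen, and the compounds shown do not tell which of these carries the step. A propylamino or a pentyl group on the same carbonyl carbon would separate the two contributions.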